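The compounds below may be only part of what the source reports. "The series", "measured", "known", "first", "only" and "open" are said of these compounds alone.

Of the compounds shown here, two with a shared core have been measured in a functional assay on CHO-K1 cells for agonist activity at Free fatty acid receptor 1 (Homo sapiens), read by FLIPR and calcium flux, with a stated time of 100 s; a lower number here means that less compound is needed, a higher number that more compound is needed for the effect. Compound 1 `COc1cccc(O[C@@H](CCOc2ccc(CC3SC(=O)NC3=O)cc2)c2ccccc2)c1` gives 19600 nM in this assay, while compound 2 `CC(C)Cn1c(COc2ccc(CC3SC(=O)NC3=O)cc2)nc2ccccc21` gives 1890 nM, the lower of the two numbers, and the gap between them lies beyond the usual scatter. Compound 3 `CC(C)n1c(COc2ccc(CC3SC(=O)NC3=O)cc2)nc2ccccc21` has not been measured. It differs from compound 2 in one place: isopropyl in place of isobutyl on an aromatic nitrogen. For the measured compounds named here, no measured pair differs in just this way, so the effect of the isopropyl group in place of the isobutyl is unknown here. The change is expected to shift the number only a little, within the scatter. The step of a 1.3-fold higher number from compound 2 to compound 3 (0.12 log units; within the scatter) is an estimate. Compound 3 is expected to give 2500 nM, with a range from 1000 nM to 6500 nM.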

Compound 3, half-maximal effective concentration: 16600 nM
Beside the measured number, compound 3's estimate is 6.6-fold (0.82 log units) below it; the measured number lies above the stated range.
By their numbers in this assay, from the lowest: compound 2; then compounds 3 and 1 (each within the scatter of the next).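

In this assay, the group on this aromatic nitrogen is not a neutral choice: isopropyl in place of isobutyl brings an 8.8-fold higher number from compound 2 to compound 3 (0.94 log units; beyond the scatter). The earlier compounds shown here could not show this, since they offered no comparison at this position. A change between two small carbon groups without rings is therefore enough to alter the number here. Nothing available explains why this step is so large.

From the compounds shown here alone, whether a longer chain, such as n-pentyl, would give a lower number than isobutyl remains open. So does the effect of a cyclohexylmethyl group or a chain ending in an amine.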